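Adding a Hydroxy Group to Compound 2

This account rests on a few compounds, and the source may have more. Where it says the series, first, only, none or still open, it means among the compounds named here.

Measured so far:
compound 1 `Brc1cc(NCc2ccccc2)c2cn[nH]c2c1` gives 37% in an assay for inhibition of Indoleamine 2,3-dioxygenase 1 (Homo sapiens), read by spectrophotometry, with a stated time of 180 min, tested at 10 uM; on this read-out lower numbers stand for a weaker effect and higher numbers for a stronger effect at the one concentration tested
compound 2 `O=C(O)c1cccc(CNc2cc(Br)cc3[nH]ncc23)c1` gives 21% in this assay

Going by the values given here, compound 2 stands lowest of the two numbers so far; its nearest neighbour is compound 1, and the single measured step, a number 16 percentage points lower from compound 1 to compound 2 (beyond the scatter), accompanied carboxy in place of hydrogen on an aromatic carbon. Compound 3 `O=C(O)c1cc(CNc2cc(Br)cc3[nH]ncc23)ccc1O` has not yet been measured. It differs from compound 2 by hydroxy in place of hydrogen on an aromatic carbon. Among the compounds with values here, no measured step involves a hydroxy group, and the only step in hand concerns a different group, so nothing among the measured compounds sets a direction for this change. A step within the scatter is therefore expected. For compound 3 the expected step from its parent is a number 1 percentage points higher from compound 2 to compound 3 (within the scatter). Compound 3 is estimated to give 22% in this assay, with a range from 5% to 40%.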

Compound 3, a percentage reported as inhibition, at one concentration (the size of the read-out at that concentration, not a potency): 38%
Estimate against measurement, compound 3: 16 percentage points below; the range from low to high includes it.
By their numbers in this assay, from the lowest: compound 2; then compounds 1 and 3 (each within the scatter of the next).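

In this assay, going by these compounds alone, the first measured change at this position, hydroxy in place of hydrogen on an aromatic carbon ortho to a carboxy group and para to a large group, goes with a number 17 percentage points higher from compound 2 to compound 3 (beyond the scatter) on the same ring that had received the carboxy group. This step runs in the opposite direction to a number 16 percentage points lower from compound 1 to compound 2 (beyond the scatter) and is of similar size, so a second substituent on this ring can raise the number as well as lower it. Nothing shown here bears on what lies behind the rise.

The compounds shown leave open whether the hydroxy group would give a step of this size without the carboxy group beside which it was measured here. They also leave open whether a methoxy group or an amine in the same place would move the number in the same direction.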